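Neutral Hydroxyalkyl Side Chain in Place of a Diethylaminoethyl Group

The source may report more compounds than this note shows. Statements on the series, on what has been measured and on what is new or still open speak of the compounds shown alone.

Measured compounds:
Compound 1 `CCN(CC)CCNC(=O)c1ccc(C(CC)(CC)c2ccc(OCCC(O)(CC)CC)c(C)c2)n1CC`: 2290 nM
Compound 2 `CCn1c(C(=O)NCCN)ccc1C(CC)(CC)c1ccc(OCCC(O)(CC)CC)c(C)c1`: 2940 nM
Compound 3 `CCn1c(C(=O)Nc2ccc(OC(F)(F)F)cc2)ccc1C(CC)(CC)c1ccc(OCCC(O)(CC)CC)c(C)c1`: > 50000 nM

In an ADME assay on L02 cells (Homo sapiens) for antiproliferative activity, read by MTT assay, with a stated time of 48 h (on this read-out higher numbers stand for weaker inhibition and lower numbers for stronger inhibition), compound 1 gives the lowest of the two numbers reported; compound 2 lies within the scatter of it, as a 1.3-fold higher number from compound 1 to compound 2 (0.11 log units; within the scatter) shows. For compound 3 the result is only a limit of the assay, (the limit of > 50000 nM in this assay, at which 1 of the 3 values shown sits). Compound 4 `CCC(C)C(CO)NC(=O)c1ccc(C(CC)(CC)c2ccc(OCCC(O)(CC)CC)c(C)c2)n1CC` differs from compound 1 in one place: 1-(hydroxymethyl)-2-methylbutyl in place of 2-(diethylamino)ethyl on an amide-type nitrogen. Within the data shown here, two measured steps bear on this. The small step of a 1.3-fold higher number from compound 1 to compound 2 (0.11 log units; within the scatter) keeps a chain carrying a nitrogen on the amide-type nitrogen, whereas the large step of an at least 21-fold higher number from compound 1 to compound 3 (1.33 log units; beyond the scatter) removes it entirely. Compound 4 also removes that nitrogen but keeps a flexible chain with a hydroxyl, so a moderate weakening is expected: a 3.5-fold higher number from compound 1 to compound 4 (0.54 log units; beyond the scatter). Compound 4 is estimated at 8000 nM, within 2500 nM to 40000 nM.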

Compound 4, half-maximal inhibitory concentration: > 50000 nM
Compound 4 gave a limit, no number; the forecaster's own chance of this, stated with the estimate: 25%; middle value at least 6.2-fold (0.79 log units) away from the limit.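

Putting 1-(hydroxymethyl)-2-methylbutyl on the amide-type nitrogen gives an at least 21-fold higher number from compound 1 to compound 4 (1.33 log units; beyond the scatter), and likewise an at least 17-fold higher number from compound 2 to compound 4 (1.23 log units; beyond the scatter). So a flexible chain with a hydroxyl does not preserve the inhibition seen with the two amine-bearing chains; among these four compounds, only those two give readable numbers. Compound 4 gives a limit, not a number, and the step from compound 3 cannot be read: the limit of > 50000 nM in this assay, at which 2 of the 4 values shown sit.

Compound 4 swaps the amine for a hydroxyl and also changes the chain's shape, so the two changes cannot be separated. A straight 2-hydroxyethyl chain, or a branched chain ending in an amine, would leave that question open here.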